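Varying the amide acyl group on a shared sulfonate core

The source may report more compounds than this note shows. Statements on the series, on what has been measured and on what is new or still open speak of the compounds shown alone.

For the measured compounds named here, compound 3 `CC(C)(C)C(=O)Nc1ccc(S(=O)(=O)Oc2ccccc2I)cc1` has the lowest number of the three compounds measured so far in a functional assay on M21 cells (Homo sapiens) for antiproliferative activity, read by sulforhodamine B assay, with a stated time of 48 h (on this read-out lower numbers stand for stronger inhibition and higher numbers for weaker inhibition), where compound 3 gives 8300 nM. Compound 2 `CCCCCC(=O)Nc1ccc(S(=O)(=O)Oc2ccccc2I)cc1` gives 11000 nM in this assay, and the gap between them, a 1.3-fold lower number from compound 2 to compound 3 (0.12 log units; within the scatter), is within the scatter. Compound 1 `CC(=O)Nc1ccc(S(=O)(=O)Oc2ccccc2I)cc1` gives 27000 nM, and the step of a 3.3-fold lower number from compound 1 to compound 3 (0.51 log units; beyond the scatter) lies beyond the scatter.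

Compound 4 `O=C(CCCCl)Nc1ccc(S(=O)(=O)Oc2ccccc2I)cc1` differs from compound 3 by one change: 3-chloropropyl in place of tert-butyl on a carbonyl carbon. Going by the values given here, two measured steps bear on this part of the molecule. The step of a 2.5-fold lower number from compound 1 to compound 2 (0.39 log units; beyond the scatter) and the step of a 3.3-fold lower number from compound 1 to compound 3 (0.51 log units; beyond the scatter) both lowered the number modestly when a larger acyl group replaced the acetyl group, while the step of a 1.3-fold lower number from compound 2 to compound 3 (0.12 log units; within the scatter) shows that the shape of that larger group made no difference beyond the scatter. A 3-chloropropyl group is another group of the same size, so compound 4 is expected to land close to compound 3, with the step of a 1.2-fold higher number from compound 3 to compound 4 (0.08 log units; within the scatter) estimated to stay within the scatter. Compound 4 is therefore estimated at 10000 nM in this assay, within a range from 4000 nM to 25000 nM.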

Compound 4, half-maximal inhibitory concentration: 7200 nM
The estimate for compound 4 lay 1.4-fold (0.14 log units) above the measured number; low and high end bracket the measured number.
By their numbers in this assay, from the lowest: compounds 4, 3 and 2 (each within the scatter of the next); then compound 1.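

In this assay, the step of a 1.2-fold lower number from compound 3 to compound 4 (0.06 log units; within the scatter) and the step of a 1.5-fold lower number from compound 2 to compound 4 (0.18 log units; within the scatter) both stay within the scatter, so a chain ending in chlorine cannot be told apart from either the branched tert-butyl group or the unbranched pentyl group. The step of a 3.8-fold lower number from compound 1 to compound 4 (0.57 log units; beyond the scatter) lies beyond the scatter, which makes 3-chloropropyl the third larger group, after pentyl and tert-butyl, to give a lower number than the methyl of compound 1, and none of the compounds shown goes against this. No measurement shown here gives a reason for these numbers.

Still open, on these data alone, is whether the acyl group can carry an amine, a carboxylic acid or a phenyl ring and keep numbers like these. Also open, as far as these compounds go, is what a chain longer than pentyl would give.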